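A few compounds are considered here, and "the series" means these few. Any claim that something is new, unique, unknown or untested is made for them only; others in the source may bear on it.

Among the measured compounds shown here, in an ADME assay on microsomes from liver (Homo sapiens) for metabolic stability, read by LC-MS, using NADPH, with a stated time of 10 min, tested at 0.1 uM (on this read-out higher numbers stand for fast clearance and lower numbers for slow clearance), compound 1 (`COc1ccc(F)cc1N1C(=O)CSC1c1cccc(C(=O)NCCCCn2cccn2)c1`) gives 421 mL.min-1.g-1 as the lower of the two numbers measured so far, while compound 2 (`COc1ccc(F)cc1N1C(=O)CSC1c1cccc(C(=O)NCCCCc2ccccc2)c1`) gives 1250 mL.min-1.g-1 as the higher one. Compound 3 (`O=C(NCCCCn1cccn1)c1cccc(C2SCC(=O)N2c2ccccn2)c1`) has not yet been measured. It differs from compound 1 by pyridin-2-yl in place of 5-fluoro-2-methoxyphenyl on an amide-type nitrogen in a ring and carries pyridin-2-yl in place of 5-fluoro-2-methoxyphenyl on an amide-type nitrogen in a ring. For the measured compounds named here, the only measured step is a 3.0-fold higher number from compound 1 to compound 2 (0.47 log units; beyond the scatter) and it concerns the group on the saturated chain, so it bears on this change only indirectly. It suggests that exchanging one ring group can move this assay by a modest amount. Going by the values given here, a step of similar size towards lower numbers is expected, although no measured compound fixes that direction. The expected step is a 1.9-fold lower number from compound 1 to compound 3 (0.28 log units; within the scatter) on this estimate. Compound 3 is expected at 220 mL.min-1.g-1 with an estimated range from 80 mL.min-1.g-1 to 600 mL.min-1.g-1 before measurement.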

Compound 3, intrinsic clearance in microsomes: 82.1 mL.min-1.g-1
Estimate against measurement, compound 3: 2.7-fold (0.43 log units) above; the range from low to high includes it.
By their numbers in this assay, from the lowest: compound 3; then compound 1; then compound 2.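

In this assay, the group on the amide-type nitrogen in the ring proves able to move the read-out on its own: with the 1H-pyrazol-1-yl chain unchanged, pyridin-2-yl in place of 5-fluoro-2-methoxyphenyl gives a 5.1-fold lower number from compound 1 to compound 3 (0.71 log units; beyond the scatter). Clearance can therefore be shifted at this position as well as at the chain end, and here the step runs towards lower numbers, whereas the chain exchange gave a 3.0-fold higher number from compound 1 to compound 2 (0.47 log units; beyond the scatter). No measurement at hand gives a reason for the step at the ring nitrogen.

The compounds shown do not separate the contributions of the fluorine, the methoxy group and the ring nitrogen, which a plain phenyl or a pyridin-3-yl group at this position could begin to do. From the compounds shown here alone, it also remains open whether pyridin-2-yl would lower the number to a similar extent with the phenyl chain end of compound 2.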